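The source may hold more compounds than are shown below. What is called first, only, known or untested is meant among the compounds shown, and "the series" means these compounds.

Working notes on the series. Compound 3 `COc1cccc(CNCCCNc2ccnc3cc(Oc4ccc(C(C)(C)C)cc4)ccc23)c1O` stands lowest of the three numbers in an ADME assay on HepG2 cells (Homo sapiens) for cytotoxicity, read by luminescence, CellTiter-Glo and ATP content, with a stated time of 72 h (a higher number here means that more compound is needed for the effect, a lower number that less compound is needed), giving 1500 nM. Compound 1 `COc1cccc(CNCCCNc2ccnc3cc(Cc4ccc(F)cc4)ccc23)c1O` gives 4780 nM in this assay, and compound 2 `COc1cccc(CNCCCNc2ccnc3cc(-c4cccc5ccccc45)ccc23)c1O` gives 2520 nM. Within the data shown here, the only step beyond the scatter is a 3.2-fold lower number from compound 1 to compound 3 (0.50 log units; beyond the scatter); the steps of a 1.9-fold lower number from compound 1 to compound 2 (0.28 log units; within the scatter) and a 1.7-fold lower number from compound 2 to compound 3 (0.23 log units; within the scatter) both lie within it.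

Compound 4 `COc1cccc(CNCCCNc2ccnc3cc(Cc4ccc(F)cc4Cl)ccc23)c1O` is not yet measured in this assay. It differs from compound 3 by 2-chloro-4-fluorobenzyl in place of 4-(tert-butyl)phenoxy on an aromatic carbon. The group that enters is a 2-chloro-4-fluorobenzyl, which resembles the 4-fluorobenzyl of compound 1; the closest guide is therefore the step of a 3.2-fold lower number from compound 1 to compound 3 (0.50 log units; beyond the scatter) read in reverse, which suggests that taking the 4-(tert-butyl)phenoxy away and putting a benzyl back raises the number modestly. Among the measured compounds shown here, no measured step tells how the added chlorine in 2-chloro-4-fluorobenzyl changes matters, so the expectation is placed between compound 3 and compound 1. For compound 4 the number in this assay is expected to be 3300 nM, with a range of 1500 nM to 7500 nM. The expected step is a 2.2-fold higher number from compound 3 to compound 4 (0.34 log units; beyond the scatter), a modest rise beyond the scatter, resting on compound 1 at 4780 nM.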

Compound 4, half-maximal effective concentration: 2350 nM
For compound 4 the middle estimate is 1.4-fold (0.15 log units) above the measured one; the measured number falls inside the stated range.
By their numbers in this assay, from the lowest: compounds 3, 4, 2 and 1 (each within the scatter of the next, the first and the last beyond it).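

In this assay, among these compounds, a 2.0-fold lower number from compound 1 to compound 4 (0.31 log units; beyond the scatter), the first step at this position that changes the benzyl group by a single substituent rather than replacing the whole group, and it lies beyond the scatter. With the chloro in place, the benzyl-bearing compound 4 can no longer be told apart from the other two groups: a 1.6-fold higher number from compound 3 to compound 4 (0.19 log units; within the scatter) and a 1.1-fold lower number from compound 2 to compound 4 (0.03 log units; within the scatter) both lie within the scatter. Nothing at hand accounts for the effect of the chloro.

On these data alone, it remains open whether a bromo or a methyl in place of the chloro would give a similar step, and whether 2-chlorobenzyl without the fluorine would keep it. Also open, as far as these compounds go, is whether an amine or a carboxylic acid on this aromatic carbon would move the number outside the span of these four compounds.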